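Swapping methyl for methoxy on the outer ring

A few compounds are considered here, and "the series" means these few. Any claim that something is new, unique, unknown or untested is made for them only; others in the source may bear on it.

Of the compounds shown here, three built on a shared core have been measured in a physicochemical assay for lipophilicity, read by HPLC, at pH 7.5; on this read-out higher numbers stand for higher lipophilicity and lower numbers for lower lipophilicity. Compound 1 `N#Cc1c(-c2ccc(Br)cc2)nc2cnccc2c1NCC(N)=O` gives 1.9. Compound 2 `CC[C@@H](Nc1c(C#N)c(-c2ccc(-c3cccc(C)c3)cc2)nc2cnccc12)C(N)=O` gives 3, the highest of the three numbers. Compound 3 `CCOc1ccccc1-c1ccc(-c2nc3cnccc3c(N[C@H](CC)C(=O)NS(=O)(=O)C3CC3)c2C#N)cc1` gives 2.3. Compound 2 therefore stands above compound 3 by a gap beyond the scatter, and above compound 1 by a wider gap, again beyond the scatter. For the measured compounds named here, no two of these measured compounds differ in a single place, so the measured set offers no isolated step to read from.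

Compound 4 `CC[C@@H](Nc1c(C#N)c(-c2ccc(-c3cccc(OC)c3)cc2)nc2cnccc12)C(N)=O` has not yet been measured in this assay. It differs from compound 2 in one place: methoxy in place of methyl on an aromatic carbon. Going by the values given here, with no measured step of this kind among the three compounds, the expectation for compound 4 rests on the count of what leaves and what enters: a methoxy group with one hydrogen-bond acceptor replaces a methyl group with none. On that basis compound 2 to compound 4 is expected to show a modest fall in this assay, somewhat beyond the scatter rather than well beyond it.

The estimate for compound 4 is 2.5, with a range from 2.1 to 2.9. That estimate amounts to an expected step of a number 0.50 log units lower from compound 2 to compound 4 (beyond the scatter).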

Compound 4, distribution coefficient: 2.7
For compound 4 the middle estimate is 0.20 log units below the measured one, within the range that was stated.
By their numbers in this assay, from the lowest: compound 1; then compound 3; then compounds 4 and 2 (each within the scatter of the next).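

In this assay, methoxy in place of methyl on the outer ring, meta to a large group, gives a number 0.30 log units lower from compound 2 to compound 4 (within the scatter) and so leaves the two compounds indistinguishable on this read-out. For the compounds shown here, this is the first comparison here that isolates a single place, as the earlier compounds differ from one another in more than one place and could not show what this one swap does on its own. At this position, then, going from 3-methylphenyl to 3-methoxyphenyl adds an oxygen and a hydrogen-bond acceptor without a step beyond the usual scatter, although no measurement shown here explains that outcome.

This single swap says nothing about how an amine, a hydroxyl group or a carboxylic acid would read at the same place on the ring, and those groups could give quite different numbers from the methyl and methoxy compared here. From the compounds shown here alone, it also remains open whether methoxy in place of methyl would give a similar step on a compound with a different side chain, such as the cyclopropyl sulfonyl amide carried by compound 3.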